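The source may report more compounds than this note shows. Statements on the series, on what has been measured and on what is new or still open speak of the compounds shown alone.

Of the compounds shown here, three on a shared core have been tested in a functional assay on HepG2 cells (Homo sapiens) for cytotoxicity, read by MTT assay, with a stated time of 48 h; on this read-out lower numbers stand for stronger inhibition and higher numbers for weaker inhibition. Compound 1 `O=Cc1c(O)ccc2oc(-c3ccco3)nc12` gives > 30000 nM, which is a limit of the assay and not a number. Compound 2 `CC(=O)c1c(O)ccc2oc(-c3ccccc3)nc12` likewise reaches only a limit, > 30000 nM. Within the data shown here, compound 3 `O=Cc1c(O)ccc2oc(-c3ccccc3Cl)nc12` is the single compound with a measured number, 10500 nM, and so it alone stands apart from the limit of > 30000 nM in this assay, at which 2 of the 3 values shown sit. Compound 4 `COc1ccccc1-c1nc2c(C=O)c(O)ccc2o1` has not yet been measured; it differs from compound 3 by methoxy in place of chloro on an aromatic carbon. Among the measured compounds shown here, no measured step of this kind exists among the three compounds, so the change is expected to be small in this assay, either within the scatter or a modest weakening. Compound 4 is therefore estimated at 18000 nM. The expected range for compound 4 runs from 7000 nM to 60000 nM. The expected step is a 1.7-fold higher number from compound 3 to compound 4 (0.23 log units; within the scatter).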

Compound 4, half-maximal inhibitory concentration: 10800 nM
The estimate for compound 4 lay 1.7-fold (0.22 log units) above the measured number; the measured number falls inside the stated range.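

In this assay, replacing chloro with methoxy on this aromatic carbon, ortho to a large group, gives a 1.0-fold higher number from compound 3 to compound 4 (0.01 log units; within the scatter). This first measured step on the shared core shows that the position takes methoxy in place of chloro with no change beyond the scatter, although methoxy carries 1 hydrogen-bond acceptor and chloro carries none. Compound 4 is the second compound to give a number rather than a limit of the assay: the limit of > 30000 nM in this assay, at which 2 of the 4 values shown sit.

From the compounds shown here alone, whether an amine or a carboxylic acid at this position would shift the number stays open. So does what a plain hydrogen here would give.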